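Carboxy in Place of Thiophen-2-yl: An Expected Step

The source may report more compounds than this note shows. Statements on the series, on what has been measured and on what is new or still open speak of the compounds shown alone.

Three compounds share one core and differ only in the group on an aromatic carbon: compound 1 `CCCCCCCCc1ccc(OCC(=O)Cn2nnc(-c3ccccc3Cl)n2)cc1`, compound 2 `CCCCCCCCc1ccc(OCC(=O)Cn2nnc(-c3cccnc3)n2)cc1` and compound 3 `CCCCCCCCc1ccc(OCC(=O)Cn2nnc(-c3cccs3)n2)cc1`. In an assay on microsomes from brain for inhibition of Fatty-acid amide hydrolase 1 (Rattus norvegicus), read by fluorescence and HPLC, with a stated time of 60 min (on this read-out lower numbers stand for stronger inhibition and higher numbers for weaker inhibition), compound 1 gives 32 nM, compound 2 gives 23 nM and compound 3 gives 32 nM; compound 3 stands level with compound 1, and the two together hold the highest numbers of the three. All three steps are small: a 1.4-fold lower number from compound 1 to compound 2 (0.14 log units; within the scatter), no change at the digits printed from compound 1 to compound 3 (within the scatter) and a 1.4-fold higher number from compound 2 to compound 3 (0.14 log units; within the scatter). Compound 4 `CCCCCCCCc1ccc(OCC(=O)Cn2nnc(C(=O)O)n2)cc1` carries carboxy in place of thiophen-2-yl on an aromatic carbon. Within the data shown here, none of the measured steps covers a change of this kind, since each swapped one aromatic ring for another, so the estimate rests on compound 3 alone and carries a wide range. Compound 4 is expected to give 300 nM, between 40 nM and 3000 nM. The step expected is a 9.4-fold higher number from compound 3 to compound 4 (0.97 log units; beyond the scatter).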

Compound 4, half-maximal inhibitory concentration: 41 nM
Compound 4: middle estimate off by 7.3-fold (0.86 log units), on the high side, and the stated range covers the measured number.
By their numbers in this assay, from the lowest: compounds 2, 1, 3 and 4 (each within the scatter of the next).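

Among these compounds, at this position, on an aromatic carbon of a five-membered aromatic ring with 4 nitrogen, the earlier compounds only exchanged one aromatic ring for another; carboxy has no ring, yet the step stays within the scatter (a 1.3-fold higher number from compound 3 to compound 4 (0.11 log units; within the scatter)). The same holds against the other two rings (a 1.8-fold higher number from compound 2 to compound 4 (0.25 log units; within the scatter); a 1.3-fold higher number from compound 1 to compound 4 (0.11 log units; within the scatter)), so among these four compounds an aromatic ring is not needed here for a number at this level. Nothing available explains this result. From the compounds shown here alone, whether an amine, a methyl ester or a longer alkyl chain at this place would also stay within the scatter remains open.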